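Swapping a Hydroxyalkyl Group for Dimethylamino on One Core

A few compounds are considered here, and "the series" means these few. Any claim that something is new, unique, unknown or untested is made for them only; others in the source may bear on it.

Compound 1 `COc1cc(-c2cnn3cc(OC)c(-c4cnn(C)c4)nc23)ccn1`: 530 nM
Compound 2 `CNc1nc2c(-c3ccnc(OC)c3)cnn2cc1OC`: 310 nM
Compound 3 `COc1cc(-c2cnn3cc(OC)c(C(C)(C)O)nc23)ccn1`: 2700 nM

Three compounds share one core and differ only at a single aromatic carbon. In an assay on isolated protein for inhibition of activin receptor type-2A (Homo sapiens), read by 33P incorporation, with a stated time of 20 min, in the presence of a further agent that is not named here (a lower number here means a stronger inhibitor, a higher number a weaker inhibitor), compound 1 gives 530 nM, compound 2 gives 310 nM, and compound 3 gives 2700 nM. Compound 3 thus has the highest number of the three and is the weakest inhibitor of this set: the gaps are a 5.1-fold higher number from compound 1 to compound 3 (0.71 log units; beyond the scatter) and an 8.7-fold higher number from compound 2 to compound 3 (0.94 log units; beyond the scatter), both beyond the scatter, while a 1.7-fold lower number from compound 1 to compound 2 (0.23 log units; within the scatter) stays within it.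

Compound 4 `COc1cc(-c2cnn3cc(OC)c(N(C)C)nc23)ccn1` has not yet been measured. Its change from compound 3 is dimethylamino in place of 1-hydroxy-1-methylethyl on an aromatic carbon. The measured step that bears most directly on this is an 8.7-fold higher number from compound 2 to compound 3 (0.94 log units; beyond the scatter), as methylamino in compound 2 and dimethylamino in compound 4 are the two closest groups among these compounds. Running that kind of change in reverse points toward a clearly lower number for compound 4, although whether dimethylamino fully recovers the level of compound 2 cannot be read from three compounds.

Compound 4 is therefore expected to give about 600 nM in this assay, with a likely range from 200 nM to 2000 nM. The expected step is a 4.5-fold lower number from compound 3 to compound 4 (0.65 log units; beyond the scatter).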

Compound 4, half-maximal inhibitory concentration: 3000 nM
For compound 4 the middle estimate is 5.0-fold (0.70 log units) below the measured one, and the stated range ends below it.
By their numbers in this assay, from the lowest: compounds 2 and 1 (each within the scatter of the next); then compounds 3 and 4 (each within the scatter of the next).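

Putting one methyl on the nitrogen of compound 2 gives compound 4, and in this assay this small edit is a 9.7-fold higher number from compound 2 to compound 4 (0.99 log units; beyond the scatter) and so separates methylamino from dimethylamino at this aromatic carbon far more than their similar names suggest. Dimethylamino and 1-hydroxy-1-methylethyl, by contrast, cannot be told apart here, with a 1.1-fold higher number from compound 3 to compound 4 (0.05 log units; within the scatter) even though the leaving group carries a hydrogen-bond donor and the entering group has none, while the 1-methyl-1H-pyrazol-4-yl group of compound 1 remains ahead of dimethylamino, with a 5.7-fold higher number from compound 1 to compound 4 (0.75 log units; beyond the scatter) as the step. Nothing available explains why one added methyl on this nitrogen matters so much.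

The four compounds leave open whether the hydrogen on the nitrogen of compound 2 is what counts or whether any larger group on that nitrogen gives the same loss. A plain amino group, an ethylamino group with its longer chain, and a ring amine such as morpholine at this carbon would help to separate those two readings.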